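The source may hold more compounds than are shown below. What is called first, only, known or untested is meant among the compounds shown, and "the series" means these compounds.

Among the measured compounds shown here, compound 2 `C[C@H]1[C@H](NCc2cccs2)C[C@H]2C[C@@H]1C2(C)C` is one of two compounds measured so far in an ADME assay on MDCK cells (Canis lupus familiaris) for cytotoxicity, read by microscopy, with a stated time of 48 h (a lower number here means that less compound is tolerated, a higher number that more compound is tolerated), and in this assay compound 2 gives 25000 nM. That is the higher of the two numbers; the other belongs to compound 1 `CCCc1csc(CN[C@@H]2C[C@H]3C[C@@H]([C@H]2C)C3(C)C)c1`, which in this assay gives 12500 nM. The two are joined by a single change, hydrogen in place of propyl on an aromatic carbon, and the step of a 2.0-fold higher number from compound 1 to compound 2 (0.30 log units; within the scatter) stays within the scatter.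

Compound 3 `C[C@H]1[C@H](NCc2cc(-c3ccccc3)cs2)C[C@H]2C[C@@H]1C2(C)C` has not yet been measured. It differs from compound 2 by phenyl in place of hydrogen on an aromatic carbon. For the measured compounds named here, the only measured step that bears on this change is the one in which propyl was removed from an aromatic carbon, and that step was too small to count. Going by the values given here, putting a phenyl onto an aromatic carbon is a change of the same sort in the opposite sense, and with only that one step to go on, no shift beyond the scatter is expected in this assay. The step from compound 2 to compound 3 is therefore estimated at a 2.0-fold lower number from compound 2 to compound 3 (0.30 log units; within the scatter). Compound 3 is expected to give 12500 nM in this assay, within a range from 5000 nM to 30000 nM.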

Compound 3, minimum cytotoxic concentration: 5000 nM
Estimate against measurement, compound 3: 2.5-fold (0.40 log units) above, within the range that was stated.
By their numbers in this assay, from the lowest: compound 3; then compounds 1 and 2 (each within the scatter of the next).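

In this assay, among the compounds shown here, a change on this aromatic carbon, two ring bonds from the ring sulfur, now gives a shift beyond the scatter for the first time: phenyl in place of hydrogen gives a 5.0-fold lower number from compound 2 to compound 3 (0.70 log units; beyond the scatter), whereas the earlier exchange of propyl and hydrogen stayed within the scatter. Phenyl also differs from propyl on the same carbon, with phenyl in place of propyl giving a 2.5-fold lower number from compound 1 to compound 3 (0.40 log units; beyond the scatter), so at this position the outcome depends on which group is attached, and compound 3 has the lowest number, with its steps to both other compounds beyond the scatter. Nothing available explains why phenyl lowers the number when propyl does not.

The compounds shown leave open whether the lower number belongs to phenyl in particular, or whether a cyclohexyl group, a pyridyl ring or a longer chain on this carbon would stand with compound 3 rather than with compounds 1 and 2. They also leave open whether phenyl on another carbon of the ring, or a carboxylic acid or an amine on the phenyl ring, would give a similar number.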